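Swapping the pyridin-4-yl group of compound 2

This account rests on a few compounds, and the source may have more. Where it says the series, first, only, none or still open, it means among the compounds named here.

Values in a functional assay on THP-1 cells (Homo sapiens) for inhibition, read by ELISA, with stated times of 1 h and 18 h (a lower number here means a stronger inhibitor, a higher number a weaker inhibitor), so far
- Compound 1 `NC(=O)[C@@H]1[C@H](Nc2nc(Nc3cccc(C(=O)N4CCCC4)c3)ncc2-c2ccoc2)[C@H]2C=C[C@@H]1C2` gives 40 nM
- Compound 2 `NC(=O)[C@@H]1[C@H](Nc2nc(Nc3cccc(C(=O)N4CCCC4)c3)ncc2-c2ccncc2)[C@H]2C=C[C@@H]1C2` gives 320 nM

Of these two, compound 2 (320 nM) has the higher number and is the weaker inhibitor. Compound 3 `NC(=O)[C@@H]1[C@H](Nc2nc(Nc3cccc(C(=O)N4CCCC4)c3)ncc2-c2cccc(F)c2)[C@H]2C=C[C@@H]1C2` keeps the shared core and carries 3-fluorophenyl in place of pyridin-4-yl on an aromatic carbon on the same aromatic carbon. Among the compounds with values here, only one measured step bears on this change, and it concerns that same carbon. Pyridin-4-yl in place of furan-3-yl gave an 8.0-fold higher number from compound 1 to compound 2 (0.90 log units; beyond the scatter) in this assay and so shows that the number moves with the group placed there. Within the data shown here, no measured compound carries a carbon-only aromatic ring at this carbon, so the evidence is thin. A partial return towards compound 1 (40 nM) is expected. The expected change is a 3.2-fold lower number from compound 2 to compound 3 (0.51 log units; beyond the scatter) in the direction of a lower number. The estimated value for compound 3 is 100 nM (expected range 30 nM to 350 nM).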

Compound 3, half-maximal inhibitory concentration: 870 nM
Compound 3: the middle estimate sits 8.7-fold (0.94 log units) below what was measured, and the stated range ends below it.
By their numbers in this assay, from the lowest: compound 1; then compound 2; then compound 3.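

Removing the ring nitrogen of pyridin-4-yl did not bring the number back towards that of compound 1 in this assay: 3-fluorophenyl moved it further away (a change of a 2.7-fold higher number from compound 2 to compound 3 (0.43 log units; beyond the scatter)) and left the widest gap in the series (a change of a 22-fold higher number from compound 1 to compound 3 (1.34 log units; beyond the scatter)). At this carbon, ortho to a large group, both six-membered aromatic rings therefore give higher numbers than furan-3-yl, and the carbon-only ring with fluorine gives the highest of the three. Nothing measured for these compounds explains this order.

Because this one step both removes the ring nitrogen and adds fluorine, the compounds shown cannot separate the two changes. As far as these compounds go, whether plain phenyl or thiophen-3-yl at this carbon would sit nearer compound 1 or compound 3 remains open.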